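Smaller Halogen Pattern on the Urea Aryl Ring

A few compounds are considered here, and "the series" means these few. Any claim that something is new, unique, unknown or untested is made for them only; others in the source may bear on it.

Two urea compounds on a shared core have been measured in a functional assay on MDA-MB-231 cells (Homo sapiens) for antiproliferative activity, read by MTT assay, with a stated time of 72 h; on this read-out higher numbers stand for weaker inhibition and lower numbers for stronger inhibition. Compound 1 `CCN(CC)CCn1cnnc1-c1cc(Oc2ccc(NC(=O)Nc3ccc(Cl)c(C(F)(F)F)c3)cc2F)ccn1` gives 1540 nM in this assay. Within the data shown here, compound 2 `CCN(CC)CCn1cnnc1-c1cc(Oc2ccc(NC(=O)Nc3cccc(C(F)(F)F)c3)cc2F)ccn1` gives 720 nM in this assay, the lowest of the two numbers; its nearest neighbour is compound 1, and the only measured step, a 2.1-fold lower number from compound 1 to compound 2 (0.33 log units; beyond the scatter), corresponds to hydrogen in place of chloro on an aromatic carbon of the urea aryl ring.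

Compound 3 `CCN(CC)CCn1cnnc1-c1cc(Oc2ccc(NC(=O)Nc3ccc(F)c(F)c3)cc2F)ccn1` is not yet measured. It differs from compound 2 by 3,4-difluorophenyl in place of 3-(trifluoromethyl)phenyl on an amide-type nitrogen. Among the measured compounds shown here, no measured step exchanges the trifluoromethyl group itself, so the one step at hand bears on the question only indirectly: it shows that removing a substituent from this ring moved the number by a modest amount and not more. On that basis compound 3 is expected to stay close to compound 2, with a step of roughly a 1.4-fold higher number from compound 2 to compound 3 (0.14 log units; within the scatter) that could fall either side of the scatter. The estimate for compound 3 in this assay is therefore 1000 nM, within a range from 400 nM to 2500 nM.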

Compound 3, half-maximal inhibitory concentration: 41300 nM
Compound 3: the middle estimate sits 41-fold (1.62 log units) below what was measured; measured number outside the range, above it.
By their numbers in this assay, from the lowest: compound 2; then compound 1; then compound 3.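

The exchange at this position proved far less forgiving than the earlier chloro removal suggested: in this assay, that removal gave a 2.1-fold lower number from compound 1 to compound 2 (0.33 log units; beyond the scatter), whereas 3,4-difluorophenyl in place of 3-(trifluoromethyl)phenyl on the amide-type nitrogen gave a 57-fold higher number from compound 2 to compound 3 (1.76 log units; beyond the scatter). The loss was also large when the comparison started from the 4-chloro-3-(trifluoromethyl)phenyl urea, with a 27-fold higher number from compound 1 to compound 3 (1.43 log units; beyond the scatter), so it appears from both of the trifluoromethyl-bearing rings shown. Both groups in the main exchange are single carbon-only aromatic rings with no hydrogen-bond donors or acceptors, so these counts do not separate them, and nothing available here accounts for the large step.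

The exchange removes the trifluoromethyl group and introduces two fluorines in one step, so the compounds shown cannot say how much of the change belongs to each part. They also leave open how an unsubstituted phenyl ring, or a ring carrying a single fluorine, a methoxy group or an amine, would behave on this urea nitrogen.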